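The source may hold more compounds than are shown below. What is called first, only, known or untested is meant among the compounds shown, and "the series" means these compounds.

Compound 1 (`CCCCCCc1ccc2nc(N)sc2c1`): 7 mg/kg
Compound 2 (`N#CCn1c(=N)sc2cc(OC(F)(F)F)ccc21`): 3.5 mg/kg

Both values come from a functional assay on the whole organism with Rattus norvegicus as the target (on this read-out higher numbers stand for an effect only at larger amounts of compound and lower numbers for an effect already at smaller amounts), and are all there is to go on so far. Compound 2 at 3.5 mg/kg lies within the usual scatter of compound 1, so the two cannot be told apart. Compound 3 (`CNS(=O)(=O)CCn1c(=N)sc2cc(OC(F)(F)F)ccc21`) is still unmeasured. It carries (methylsulfamoyl)methyl in place of cyano on a saturated chain carbon bound to an aromatic nitrogen. Going by the values given here, no measured pair shows what a change at this place does, so the expectation is loose and starts from compound 2 at 3.5 mg/kg in this assay. A modest shift toward larger doses is expected, estimated as a 1.7-fold higher number from compound 2 to compound 3 (0.23 log units; within the scatter) and possibly no larger than the scatter. The expected value for compound 3 is 6 mg/kg with an estimated range from 2 mg/kg to 20 mg/kg for the coming measurement.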

Compound 3, dose for half-maximal effect: 4 mg/kg
Compound 3: the middle estimate sits 1.5-fold (0.18 log units) above what was measured; the measured number falls inside the stated range.
By their numbers in this assay, from the lowest: compounds 2, 3 and 1 (each within the scatter of the next).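

In this assay, putting (methylsulfamoyl)methyl in place of cyano on a saturated chain carbon bound to an aromatic nitrogen gives a 1.1-fold higher number from compound 2 to compound 3 (0.06 log units; within the scatter) and so leaves the two compounds indistinguishable. This first measured pair at this place shows that, in this one case, the cyanomethyl chain can be exchanged for a 2-(methylsulfamoyl)ethyl chain, which brings a hydrogen-bond donor that cyano lacks, without a measurable change in the dose needed. Nothing available explains this result.

On these data alone, whether an amine or a carboxylic acid at the end of this chain would be accepted equally well remains open, as does the effect of a longer chain carrying the methylsulfamoyl group. A single pair also cannot show whether this exchange would give the same result on a different core.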